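The source may hold more compounds than are shown below. What is called first, only, known or untested is meant among the compounds shown, and "the series" means these compounds.

Measured so far in an ADME assay on Vero cells (Chlorocebus sabaeus) for cytotoxicity, read by sulforhodamine B assay, with a stated time of 72 h; a higher number here means a weaker inhibitor, a lower number a stronger inhibitor:

- compound 1 `COc1ccc2c(c1)[C@@H](O)CN(C)C2`: > 100000 nM
- compound 2 `Cc1cccc(COc2ccc3c(c2)[C@@H](O)CN(C)C3)c1`: > 50000 nM
- compound 3 `CN1Cc2ccc(OCCc3ccccc3)cc2[C@@H](O)C1`: > 50000 nM

Every value above is a limit of the assay and not a number. Compound 1 sits at the limit of > 100000 nM in this assay, at which 1 of the 3 values shown sits. Compound 2 sits at the limit of > 50000 nM in this assay, at which 2 of the 3 values shown sit. Compound 3 sits at the same limit, (the limit of > 50000 nM in this assay, at which 2 of the 3 values shown sit), so its standing on the numbers shown is only a bound, with no measured step to place it against the other two.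

The three measured steps are accordingly all unreadable: a step that the two limits leave unreadable from compound 1 to compound 2, a step that the two limits leave unreadable from compound 1 to compound 3 and a step that the two limits leave unreadable from compound 2 to compound 3. None of them gives a size or a direction.

Compound 4 `CN1Cc2ccc(OCCC3CCCCC3)cc2[C@@H](O)C1` differs from compound 3 by cyclohexyl in place of phenyl on a saturated chain carbon, two bonds along the chain from an oxygen on an aromatic ring. For the measured compounds named here, the only step that bears on this change is the one from compound 2 to compound 3, and it is unreadable; the others concern the same chain position but not this exchange. The expectation is therefore for no step beyond the scatter, a step that the limit leaves unreadable from compound 3 to compound 4, and for compound 4 to be reported at a limit rather than a number in this assay. The estimate for compound 4 is 70000 nM, with a range from 30000 nM to 200000 nM.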

Compound 4, half-maximal inhibitory concentration: > 50000 nM
Compound 4: a limit, no number (the forecaster's own chance of this, stated with the estimate: 85%); the middle value lies beyond the limit too.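

In this assay compound 4 gives > 50000 nM, a limit and not a number. For the compounds shown here, no step from compound 1, compound 2 or compound 3 to compound 4 can be read. The compounds shown leave open whether any change on the chain shifts the value in this assay, as all four stand at limits.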